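The source may report more compounds than this note shows. Statements on the series, on what has been measured and on what is new or still open speak of the compounds shown alone.

In a functional assay on NSCLC cells (Homo sapiens) for inhibition (on this read-out lower numbers stand for stronger inhibition of growth and higher numbers for weaker inhibition of growth), three compounds have been measured:

- compound 1 `COc1ccc(-c2nc3sc(Cc4ccccc4)nn3c2SC#N)cc1`: 4600 nM
- compound 2 `Clc1ccc(-c2cn3nc(Cc4ccccc4)sc3n2)cc1`: 7600 nM
- compound 3 `O=Cc1c(-c2ccc(Br)cc2)nc2sc(Cc3ccccc3)nn12`: 4200 nM

The three share a common core and differ in the group hanging from it and in the substituent on the attached phenyl ring. Of the three numbers, that of compound 3 is the smallest, but its gap to compound 1 is tiny and its gap to compound 2 is also within the usual scatter of this kind of measurement, so none of the three can be told apart from the others with confidence. No pair of these compounds differs in only one place, so no single structural change can be read from them.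

Compound 4 `O=Cc1c(-c2ccc([N+](=O)[O-])cc2)nc2sc(Cc3ccccc3)nn12` has not yet been measured. It is built from compound 3 by one change: nitro in place of bromo on an aromatic carbon. Among the measured compounds shown here, nothing among the measured compounds shows what this particular exchange does, and the three values so far sit close together. The expectation is therefore a step of a 1.1-fold lower number from compound 3 to compound 4 (0.02 log units; within the scatter), not beyond the scatter in either direction. On that basis compound 4 is estimated to give 4000 nM in this assay, most likely between 1500 nM and 12000 nM.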

Compound 4, concentration for 50% growth inhibition: 2900 nM
The estimate for compound 4 lay 1.4-fold (0.14 log units) above the measured number, within the range that was stated.
By their numbers in this assay, from the lowest: compounds 4, 3, 1 and 2 (each within the scatter of the next, the first and the last beyond it).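

In this assay, among the compounds shown here, nitro in place of bromo on an aromatic carbon, para to a large group, gives a 1.4-fold lower number from compound 3 to compound 4 (0.16 log units; within the scatter) and provides the first comparison here in which only one place differs. Earlier, the gaps between compounds could not be tied to any single exchange, whereas this pair isolates one position on the six-membered aromatic ring. At this position, a single bromine can be replaced by nitro, with its three heavy atoms and two hydrogen-bond acceptors, without a step beyond the scatter, though one exchange says little about the position as a whole, and no measured property of either group is available to explain the result.

Still open, going by these compounds, is whether a quite different group at this position, such as an amine, a carboxylic acid or a longer chain, would produce a step beyond the scatter. Also open is how much the carbonyl-bearing group on the shared core of compound 3 and compound 4 contributes, since no pair shown isolates that group from its replacements.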